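Thiocarbonyl Replacement on the Piperidine Carbamate

The compounds below may be only part of what the source reports. "The series", "measured", "known", "first", "only" and "open" are said of these compounds alone.

Measured compounds:
- Compound 1, `CC(C)(C)OC(=O)N1CCC(Oc2cccc3c2CCN3c2ccc(S(C)(=O)=O)cc2)CC1`: 158 nM
- Compound 2, `CC(C)OC(=O)N1CCC(Oc2ncnc3c2CCN3c2ccc(S(C)(=O)=O)cc2)CC1`: 126 nM
- Compound 3, `CCCOC(=O)N1CCC(Oc2ncnc3c2CCN3c2ccc(S(C)(=O)=O)cc2F)CC1`: 79.4 nM

In a functional assay on CHO-K1 cells for agonist activity at Glucose-dependent insulinotropic receptor (Homo sapiens), read by a luciferase reporter, with a stated time of 5 h (a higher number here means that more compound is needed for the effect, a lower number that less compound is needed), compound 3 gives 79.4 nM. Of the three numbers this is the lowest, but it sits within the usual scatter of both compound 2 and compound 1, so the three measured carbamates cannot be told apart on these data; the alkoxy group on the carbonyl carbon, whether tert-butoxy, isopropoxy or propoxy, has left no trace beyond the noise.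

Compound 4, `CSC(=O)N1CCC(Oc2ncnc3c2CCN3c2ccc(S(C)(=O)=O)cc2F)CC1`, is the next step from compound 3. The change is methylsulfanyl in place of propoxy on a carbonyl carbon. Going by the values given here, no measured pair in this set shows what such a change does, and the account therefore rests only on the indifference of this assay to the three alkoxy groups already tested. The step from compound 3 to compound 4 is expected to be small, with a slight lean towards a higher number, and a 1.9-fold higher number from compound 3 to compound 4 (0.28 log units; within the scatter) is the estimate that follows. On that basis compound 4 is expected to give 150 nM in this assay, with a likely range from 50 nM to 500 nM.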

Compound 4, half-maximal effective concentration: 251 nM
For compound 4 the middle estimate is 1.7-fold (0.22 log units) below the measured one, and the stated range covers the measured number.
By their numbers in this assay, from the lowest: compounds 3, 2, 1 and 4 (each within the scatter of the next, the first and the last beyond it).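

Methylsulfanyl in place of propoxy on a carbonyl carbon gives a 3.2-fold higher number from compound 3 to compound 4 (0.50 log units; beyond the scatter) in this assay and is the first change in this set confined to one place, which shows that the group at this position can move the number beyond the scatter. The change is not a single one, however: the group that enters carries sulfur where the group that leaves carries oxygen, and its chain is also shorter, so this one pair cannot separate the two differences. No measurement of any other kind accompanies this step, and nothing here accounts for it.

As far as these compounds go, whether the higher number goes with the sulfur or with the shorter chain stays open, and methoxy or propylsulfanyl on the same carbonyl carbon would separate the two. An amine on this carbonyl carbon, giving a urea, or a plain alkyl chain, giving an amide, lies outside the compounds shown, so how this position responds to a link through neither oxygen nor sulfur remains unknown.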